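The source may report more compounds than this note shows. Statements on the series, on what has been measured and on what is new or still open speak of the compounds shown alone.

Compound 2 `CCSC(=O)C1=C(C)NC(=O)NC1c1ccsc1` is one of two compounds tested in an assay on membranes from CHO cells for displacement of a labelled ligand from adenosine receptor A1 (Homo sapiens), read by scintillation counting, with a stated time of 60 min, tested at 1 uM; a higher number here means more inhibition at the concentration tested (going by the name of the read-out), a lower number less inhibition. In this assay compound 2 gives 11%. Among the compounds with values here, its only neighbour is compound 1 `CCCC(=O)C1=C(C)NC(=O)NC1c1ccsc1`, which in this assay gives 6%. Within the data shown here, the one measured step, a number 5 percentage points higher from compound 1 to compound 2 (within the scatter), swaps ethylsulfanyl for propyl on a carbonyl carbon; its size lies within the scatter, so the two numbers cannot be ranked, and both show little inhibition at the concentration tested.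

Compound 3 `CC1=C(c2ncc(C)o2)C(c2ccsc2)NC(=O)N1` has not yet been measured. It differs from compound 2 in one place: 5-methyl-1,3-oxazol-2-yl in place of (ethylsulfanyl)carbonyl on a double-bonded ring carbon. This change touches a different part of the shared core than the measured step did, which concerned only the chain on the carbonyl carbon. Among the measured compounds shown here, no measured step therefore bears directly on it, and the two numbers so far merely say that this core, with either chain, inhibits weakly.

On that basis the expected step of a number 1 percentage points lower from compound 2 to compound 3 (within the scatter) is none beyond the scatter. Compound 3 is estimated at 10%, with a range from -5% to 30%.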

Compound 3, a percentage reported as inhibition, at one concentration (the size of the read-out at that concentration, not a potency): 34%
For compound 3 the middle estimate is 24 percentage points below the measured one; measured number outside the range, above it.
By their numbers in this assay, from the lowest: compounds 1 and 2 (each within the scatter of the next); then compound 3.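

In this assay the double-bonded ring carbon proves to be a place where the read-out responds: putting 5-methyl-1,3-oxazol-2-yl there gives a number 23 percentage points higher from compound 2 to compound 3 (beyond the scatter) when it replaces (ethylsulfanyl)carbonyl and a number 28 percentage points higher from compound 1 to compound 3 (beyond the scatter) when it replaces propylcarbonyl. The earlier step only exchanged what sits on the carbonyl carbon and stayed within the scatter, whereas this change removes the carbonyl group altogether and brings in a five-membered aromatic ring, with the counts of hydrogen-bond donors and acceptors the same in the groups that leave and enter. Nothing measured here explains why this exchange raises the inhibition.

The compounds shown leave open whether the rise belongs to the ring itself or to its methyl group, which a plain 1,3-oxazol-2-yl would separate, and whether a simple primary amide at this carbon would behave like the ring or like the carbonyl groups. As far as these compounds go, it is also open whether the step keeps its size with a phenyl group in place of the thiophen-3-yl group, since that group stays the same throughout.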